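Swapping a diol for an ester: the cytotoxicity outlook

The source may hold more compounds than are shown below. What is called first, only, known or untested is meant among the compounds shown, and "the series" means these compounds.

Compound 1 `N#Cc1ccc(Cn2nc(-c3cc(Cl)c(NC[C@H](O)CO)nc3F)c3ccccc3c2=O)cc1` and compound 2 `COC(=O)c1cc(-c2ccc(F)nc2F)nn(Cc2ccc(Cl)cc2)c1=O` have both been run in an ADME assay on HepG2 2.2.15 cells (Homo sapiens) for cytotoxicity, read by MTT assay, with a stated time of 8 days; a lower number here means that less compound is tolerated, a higher number that more compound is tolerated. For compound 1 the read-out is a limit rather than a number, > 100000 nM. For compound 2 the read-out is also a limit, > 100000 nM. Compound 1 thus stands at the limit of > 100000 nM in this assay, at which 2 of the 2 values shown sit, so no measured difference between it and compound 2 can be read from these two values. Compound 3 `COC(=O)CCNc1nc(F)c(-c2nn(Cc3ccc(C#N)cc3)c(=O)c3ccccc23)cc1Cl` has not yet been tested in this assay. It differs from compound 1 in a single place: (methoxycarbonyl)methyl in place of 1,2-dihydroxyethyl on a saturated chain carbon bound to a nitrogen on an aromatic ring. Within the data shown here, no step between measured compounds is available, and both known values sit at the same limit, so no change beyond the usual scatter is expected here. The step of a number no higher from compound 1 to compound 3 (the limit leaves the size open) is estimated to be negligible. Compound 3 is expected to give about 100000 nM, somewhere within 40000 nM to 250000 nM, and most likely to be reported once more only as a limit.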

Compound 3, half-maximal cytotoxic concentration: > 100000 nM
Compound 3 ended at the assay's limit; the forecaster's own chance of this, stated with the estimate: 75%; the middle value lies on the limit itself.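

Among these compounds, compound 1 and compound 3 both stop at a limit in this assay, so no step between them can be read. Going by these compounds, what stays open is where either compound's true half-maximal cytotoxic concentration lies, and whether replacing 1,2-dihydroxyethyl with (methoxycarbonyl)methyl changes it at all.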